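A few compounds are considered here, and "the series" means these few. Any claim that something is new, unique, unknown or untested is made for them only; others in the source may bear on it.

In a functional assay on the whole organism with Mus musculus as the target (on this read-out lower numbers stand for smaller maximal responses and higher numbers for larger maximal responses), compound 1 `Nc1nc(O)c2c(n1)n(C1OC(CO)[C@@H](O)[C@H]1O)c(=O)n2Cc1ccc(Cl)c(Cl)c1` gives 0%. Compound 2 `C=CCn1c(=O)n(C2CCC(CO)C2)c2nc(N)nc(O)c21` gives in this assay a reading of 0%, so compound 2 stands level with compound 1 at the digits shown, and the two values lie within the scatter of each other. Compound 3 `C=CCn1c(=O)n([C@H]2CO[C@@H](CO)C2)c2nc(N)nc(O)c21` has not yet been measured. It differs from compound 2 by a group of 7 heavy atoms (5 carbon, 2 oxygen; one five-membered non-aromatic ring with 1 hetero atom) in place of a group of 7 heavy atoms (6 carbon, 1 oxygen; one five-membered non-aromatic ring of carbon only), on an aromatic nitrogen. For the measured compounds named here, no step between two measured compounds involves a change of this kind, so the size of the step in this assay cannot be read from a precedent. Because compound 2 gives 0% and compound 1 likewise gives 0%, no change beyond the scatter is expected in either direction. The step of no change at the digits printed from compound 2 to compound 3 (within the scatter) is estimated to be none beyond the scatter. Compound 3 is expected to give 0%, with a range from 0% to 10%.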

Compound 3, largest response reached (reported as maximal response), in percent of the reference or control that the assay uses: 16%
Beside the measured number, compound 3's estimate is 16 percentage points below it, and the stated range ends below it.
By their numbers in this assay, from the lowest: compounds 1 and 2 (each within the scatter of the next); then compound 3.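

In this assay, the exchange on the aromatic nitrogen gives a number 16 percentage points higher from compound 2 to compound 3 (beyond the scatter), whereas compound 1 and compound 2 had shown no difference beyond the scatter. The result shows that this position can register a change in the read-out even when the group stays at 7 heavy atoms, with the carbon-only five-membered ring replaced by a five-membered ring with 1 hetero atom. No measurement at hand accounts for this rise.

The entering group brings both the ring oxygen and 2 defined stereocentres, and these compounds do not separate the two changes. They also leave open how the reading would respond to a carboxylic acid or an amine on that ring, or to a longer chain in place of the allyl group.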